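This account rests on a few compounds, and the source may have more. Where it says the series, first, only, none or still open, it means among the compounds named here.

Measured compounds in a toxicity assay on THP-1 cells (Homo sapiens) for inhibition; a lower number here means that less compound is tolerated, a higher number that more compound is tolerated:
Compound 1 `COc1ccc(-c2cnc(NC(=O)c3cccc(OC)c3)n2C)cc1` gives > 100000 nM, a limit of this assay rather than a number.
Compound 2 `COc1ccc(-c2ccnc(NC(=O)c3ccc(F)cc3)c2)cc1` gives > 100000 nM, also a limit.
Compound 3 `COc1ccc(-c2cnc(NC(=O)c3cccc([N+](=O)[O-])c3)n2C)cc1` gives > 100000 nM, also a limit.

Compound 1 thus stands only at a limit in this assay, and the two further values shown sit at the same limit (the limit of > 100000 nM in this assay, at which 3 of the 3 values shown sit). Compound 4 `COc1ccc(-c2cnc(NC(=O)c3ccccc3Br)n2C)cc1` differs from compound 1 by 2-bromophenyl in place of 3-methoxyphenyl on a carbonyl carbon. Going by the values given here, the only measured step at the carbonyl position, a step that the two limits leave unreadable from compound 1 to compound 3, is unreadable, both ends sitting at the limit (the limit of > 100000 nM in this assay, at which 3 of the 3 values shown sit). Among the compounds with values here, no measured step therefore gives a size or direction for this change, and nothing among the values shown points away from the limit. Compound 4 is expected to stay at the limit as well, estimated at 100000 nM (range 30000 nM to 300000 nM), meaning a step of a number no higher from compound 1 to compound 4 (the limit leaves the size open).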

Compound 4, half-maximal cytotoxic concentration: > 100000 nM
Compound 4: only a limit was reported (the forecaster's own chance of this, stated with the estimate: 85%); the middle value sits exactly at the limit.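

The step from compound 1 to compound 4 cannot be read, both compounds sitting at a limit in this assay: the limit of > 100000 nM in this assay, at which 4 of the 4 values shown sit.

The compounds shown leave open at what concentration any of them reaches half-maximal cytotoxicity, and whether any change on the carbonyl carbon shifts it.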